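Replacing 4-chloropyridin-2-yl with 4-methoxyphenyl on the carbonyl carbon

A few compounds are considered here, and "the series" means these few. Any claim that something is new, unique, unknown or untested is made for them only; others in the source may bear on it.

Measured in a functional assay on HUVEC cells (Homo sapiens) for inhibition, with stated times of 2 h and 72 h; a lower number here means a stronger inhibitor, a higher number a weaker inhibitor:
- Compound 1 `COc1cc2nccc(Oc3ccc4c(NC(=O)Nc5ccc(C(F)(F)F)cc5Cl)nn(C)c4c3)c2cc1OC`: 1150 nM
- Compound 2 `COc1cc2nccc(Oc3ccc4c(NC(=O)c5cc(Cl)ccn5)nn(C)c4c3)c2cc1OC`: 27 nM

Of these two, compound 2 holds the lower number. Going by the values given here, the one measured step is a 43-fold lower number from compound 1 to compound 2 (1.63 log units; beyond the scatter), and it placed 4-chloropyridin-2-yl on a carbonyl carbon.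

Compound 3 `COc1ccc(C(=O)Nc2nn(C)c3cc(Oc4ccnc5cc(OC)c(OC)cc45)ccc23)cc1` keeps the shared core and changes the group at that same place, with 4-methoxyphenyl in place of 4-chloropyridin-2-yl on a carbonyl carbon. The measured step bears on this change only in part. Among the compounds with values here, it touches the same carbonyl carbon, but the group it exchanged for 4-chloropyridin-2-yl was a different one, and no measured compound carries 4-methoxyphenyl. A step as large as that one is therefore not expected in this assay. Within the data shown here, a moderate move toward a higher number seems more likely, since compound 2 is the lower of only two values, though the data do not settle the direction. The expected step is a 2.6-fold higher number from compound 2 to compound 3 (0.41 log units; beyond the scatter). Compound 3 is estimated at 70 nM, with an expected range of 20 nM to 300 nM.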

Compound 3, half-maximal inhibitory concentration: 32 nM
Compound 3: middle estimate off by 2.2-fold (0.34 log units), on the high side; the range from low to high includes it.
By their numbers in this assay, from the lowest: compounds 2 and 3 (each within the scatter of the next); then compound 1.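

In this assay, a 1.2-fold higher number from compound 2 to compound 3 (0.07 log units; within the scatter) shows that the carbonyl carbon tolerates more than one group: 4-methoxyphenyl, with its six-membered aromatic ring of carbon only, reads the same within the scatter as 4-chloropyridin-2-yl, with its one ring hetero atom and its chlorine. Going by these compounds alone, the large drop seen earlier is therefore not peculiar to 4-chloropyridin-2-yl, since a 36-fold lower number from compound 1 to compound 3 (1.56 log units; beyond the scatter) is of similar size and also lies beyond the scatter, with compound 1 and its (2-chloro-4-(trifluoromethyl)phenyl)amino group as the only one of the three compounds with a much higher number. Nothing in the data at hand accounts for why these two groups give matching results.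

Compound 1 differs from compound 2 and compound 3 both in the amino nitrogen on the carbonyl carbon and in the substituents on its ring, so the compounds shown do not separate these two features. A (4-methoxyphenyl)amino group on the carbonyl carbon would address that question, while a plain phenyl or a saturated ring such as cyclohexyl would show whether the methoxy group, or an aromatic ring at all, is needed here.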